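Swapping the benzyl of compound 1 for a dimethoxyphenyl

The source may report more compounds than this note shows. Statements on the series, on what has been measured and on what is new or still open speak of the compounds shown alone.

The study measures growth inhibition in a functional assay on CCRF-CEM cells (Homo sapiens) for inhibition, read by cell counting, with a stated time of 3 days; on this read-out higher numbers stand for weaker inhibition and lower numbers for stronger inhibition. Compound 1 `C=C(Br)C(=O)Nc1cccc(-c2cn3nc(Cc4ccccc4)sc3n2)c1` gives 4200 nM in this assay, the lowest of the three numbers recorded. Where compound 1 carries the bromoacrylamide, compound 2 `Nc1cccc(-c2cn3nc(Cc4ccccc4)sc3n2)c1` carries a free amine, and compound 2 gives 37000 nM; the step of an 8.8-fold higher number from compound 1 to compound 2 (0.94 log units; beyond the scatter) shows what the acrylamide contributes. Compound 3 `Nc1cccc(-c2cn3c(-c4ccc(Cl)cc4)csc3n2)c1`, built on the core with a chlorophenyl at another position and the same free amine, gives 21000 nM.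

Compound 4 `C=C(Br)C(=O)Nc1cccc(-c2cn3nc(-c4ccc(OC)c(OC)c4)sc3n2)c1` keeps the bromoacrylamide of compound 1 and differs from it only in 3,4-dimethoxyphenyl in place of benzyl on an aromatic carbon. For the measured compounds named here, none of the measured steps changes this position; the one step recorded, from compound 1 to compound 2, concerns the amine instead. Nothing in the data therefore points to a shift in either direction, and a step within the scatter is expected, a 1.1-fold lower number from compound 1 to compound 4 (0.02 log units; within the scatter). Compound 4 is accordingly estimated at 4000 nM in this assay, with a range from 1400 nM to 12000 nM.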

Compound 4, half-maximal inhibitory concentration: 380 nM
Estimate against measurement, compound 4: 11-fold (1.02 log units) above; measured number below the stated range.
By their numbers in this assay, from the lowest: compound 4; then compound 1; then compounds 3 and 2 (each within the scatter of the next).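

In this assay, 3,4-dimethoxyphenyl in place of benzyl gives an 11-fold lower number from compound 1 to compound 4 (1.04 log units; beyond the scatter) with the bromoacrylamide unchanged, a large step beyond the scatter. The earlier step concerned only the group on the aniline nitrogen, whereas this one shows that the aromatic carbon next to the ring sulfur is also a place where a change of group moves the number strongly. No evidence is available on what lies behind this step.

The change both removes the carbon link of the benzyl and adds two methoxy groups, so the compounds shown do not tell which of these accounts for the step, and a plain phenyl or a phenyl with a single methoxy group would separate them. They also leave open whether 3,4-dimethoxyphenyl has a comparable effect alongside the free amine of compound 2.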